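Compound 3 and its 2-chlorophenyl analogue, compound 4

The compounds below may be only part of what the source reports. "The series", "measured", "known", "first", "only" and "open" are said of these compounds alone.

In a functional assay on NCI-H460 cells (Homo sapiens) for inhibition, read by MTT assay, with a stated time of 24 h, tested at 1 ug/mL (on this read-out lower numbers stand for less inhibition of growth and higher numbers for more inhibition of growth at the one concentration tested), compound 3 (`CC(=O)SCCC(CCCCC(=O)Nc1ccccc1)SC(C)=O`) gives 13.1%. Compound 1 (`CC(=O)SCCC(CCCCC(=O)O)SC(C)=O`) gives 9.89%, within the scatter of compound 3, while compound 2 (`O=C(CCCCC1CCSS1)NO`) gives 0.64%, lower than compound 3 by more than the scatter.

Compound 4 (`CC(=O)SCCC(CCCCC(=O)Nc1ccccc1Cl)SC(C)=O`) differs from compound 3 by chloro in place of hydrogen on an aromatic carbon, with chloro in place of hydrogen on an aromatic carbon, ortho to a large group. Among the measured compounds shown here, the only measured step that bears on this change is a number 3.2 percentage points higher from compound 1 to compound 3 (within the scatter), which introduces the anilino group. For the measured compounds named here, no measured compound carries a chloro, so this is weak guidance.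

An expected step of a number 0.9 percentage points higher from compound 3 to compound 4 (within the scatter) would stay within the scatter. The estimated value for compound 4 is 14%, with a range of 4% to 28%.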

Compound 4, percent growth inhibition at one concentration: 13.2%
For compound 4 the middle estimate is 0.8 percentage points above the measured one; the measured number falls inside the stated range.
By their numbers in this assay, from the lowest: compounds 2, 1, 3 and 4 (each within the scatter of the next, the first and the last beyond it).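

In this assay, among the compounds shown here, chloro in place of hydrogen on this aromatic carbon, ortho to a large group, gives a step within the scatter (a number 0.1 percentage points higher from compound 3 to compound 4 (within the scatter)), which the earlier compounds, none carrying a chloro, could not show. (2-Chlorophenyl)amino in place of hydroxy on the carbonyl carbon likewise stays within the scatter (a number 3.3 percentage points higher from compound 1 to compound 4 (within the scatter)). No measured evidence bears on this result.

Going by these compounds, it remains open whether a methoxy or a dimethylamino group in place of the chloro, or a longer chain in the core, would move the number beyond the scatter.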